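Removing a methyl from the phenol region of compound 1

This account rests on a few compounds, and the source may have more. Where it says the series, first, only, none or still open, it means among the compounds named here.

Compound 1 `COc1cc(/C=N/NC(=O)c2ccncc2)cc(OC)c1O` is the stronger of the two measured compounds in a physicochemical assay on cells (Homo sapiens), with a stated time of 18 h, tested at 1 uM (a higher number here means a weaker effect of the compound at the concentration tested, a lower number a stronger effect), where compound 1 gives 48%. Going by the values given here, its only measured neighbour is compound 2 `COc1cc(/C=N/NC(=O)c2ccncc2)cc(OC)c1OC`, in which compound 2 gives 95%, the step of a number 47 percentage points higher from compound 1 to compound 2 (beyond the scatter) arising from methyl in place of hydrogen on an oxygen on an aromatic ring. Compound 3 `COc1cc(/C=N/NC(=O)c2ccncc2)cc(O)c1O` takes the same kind of change in the opposite direction from compound 1: hydrogen in place of methyl on an oxygen on an aromatic ring. Among the compounds with values here, the one measured step that bears on it, a number 47 percentage points higher from compound 1 to compound 2 (beyond the scatter), was large and ran towards weaker effect when a methyl was added; the reverse change is therefore expected to move towards stronger effect, though its size is not fixed by a single step and may be smaller. The expected step is a number 13 percentage points lower from compound 1 to compound 3 (beyond the scatter). For compound 3 the estimate in this assay is 35%, within 15% to 60%.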

Compound 3, a percentage reported as activity, at one concentration (the size of the read-out at that concentration, not a potency): 59%
Beside the measured number, compound 3's estimate is 24 percentage points below it; measured number inside the range.
By their numbers in this assay, from the lowest: compound 1; then compound 3; then compound 2.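

In this assay the step of a number 11 percentage points higher from compound 1 to compound 3 (beyond the scatter) is the opposite of what simple reversal of the methyl change would give: taking a methyl off a methoxy group moves the number the same way as putting one on the hydroxy group. The step of a number 47 percentage points higher from compound 1 to compound 2 (beyond the scatter) is large and the new one only modest, yet both lead away from compound 1, which is the strongest of the three compounds shown, so methoxy to hydroxy here weakens the effect rather than strengthening it. Nothing on hand gives a reason for either step. Still open, from the compounds shown here alone, is how a longer chain such as ethyl on this oxygen would read, or an amine in place of the hydroxy group. Also open, going by these compounds, is whether the same methoxy to hydroxy change behaves alike on the other methoxy group.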